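The compounds below may be only part of what the source reports. "The series", "measured", "known", "first", "only" and "open" are said of these compounds alone.

Measured compounds:
- compound 1, `CCC(C)(C)Cc1c[nH]c(CCc2ccc(-n3ccnn3)cc2)n1`, gives 390 nM in an in vitro assay on CHO cells for displacement of a labelled ligand from Bombesin receptor subtype-3 (Homo sapiens), read by scintillation counting, with a stated time of 2 h; a lower number here means a stronger inhibitor, a higher number a weaker inhibitor.
- compound 2, `CCC(C)(C)Cc1c[nH]c(CCc2ccc(-c3csnn3)cc2)n1`, gives 45 nM in this assay.
- compound 3, `CCC(C)(C)Cc1c[nH]c(CCc2ccc(N3CCCCC3)cc2)n1`, gives 28 nM in this assay.

Among these three, compound 3 has the lowest number, but its step to compound 2 is within the scatter (a 1.6-fold lower number from compound 2 to compound 3 (0.21 log units; within the scatter)), so the two cannot be told apart; only compound 1 stands clearly apart, as a 14-fold lower number from compound 1 to compound 3 (1.14 log units; beyond the scatter) shows.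

Compound 4, `CCC(C)(C)Cc1c[nH]c(CCc2ccc(-c3ccns3)cc2)n1`, differs from compound 3 in one place: 1,2-thiazol-5-yl in place of piperidin-1-yl on an aromatic carbon. The step that bears most on this change is the swap of a five-membered aromatic ring with two hetero atoms for the piperidine, seen from compound 2 to compound 3, which was small (a 1.6-fold lower number from compound 2 to compound 3 (0.21 log units; within the scatter)). Among the compounds with values here, the only large move in this set came when the 1H-1,2,3-triazol-1-yl was replaced (a 14-fold lower number from compound 1 to compound 3 (1.14 log units; beyond the scatter)), and compound 4 keeps a ring more like the one in compound 2. The expected step from compound 3 to compound 4 is therefore small, a 2.1-fold higher number from compound 3 to compound 4 (0.33 log units; beyond the scatter), toward a slightly higher number but not clearly beyond the scatter. Compound 4 is estimated at 60 nM in this assay, within a range of 20 nM to 200 nM.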

Compound 4, half-maximal inhibitory concentration: 11 nM
Compound 4: the middle estimate sits 5.5-fold (0.74 log units) above what was measured; the measured number lies below the stated range.
By their numbers in this assay, from the lowest: compound 4; then compounds 3 and 2 (each within the scatter of the next); then compound 1.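

In this assay, the 1,2-thiazol-5-yl group sets compound 4 clearly apart from the two best earlier compounds, with a 2.5-fold lower number from compound 3 to compound 4 (0.41 log units; beyond the scatter) and a 4.1-fold lower number from compound 2 to compound 4 (0.61 log units; beyond the scatter), so the level shared by compound 2 and compound 3 was not the lowest this position can reach. The step of a 35-fold lower number from compound 1 to compound 4 (1.55 log units; beyond the scatter) also widens the spread among compounds that all carry a five-membered aromatic ring at this aromatic carbon, so having that kind of ring does not by itself fix the number: compound 1, compound 2 and compound 4 all have one, yet they differ clearly from one another. Nothing available explains why this particular ring gives the lowest number of the four.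

On these data alone, how a phenyl ring, a morpholine or a carboxylic acid would compare at this same aromatic carbon remains open. As far as these compounds go, all four compounds also share the same core, so it is unknown whether the 1,2-thiazol-5-yl group would still give the lowest number with a shorter chain in place of the branched alkyl chain elsewhere on that core.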